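Chlorine pattern on the shared core of dithiazole chromones

The compounds below may be only part of what the source reports. "The series", "measured", "known", "first", "only" and "open" are said of these compounds alone.

Compound 2 `O=c1c(C2N=C(c3ccccc3)SS2)coc2cc(Cl)c(Cl)cc12` carries two chloro groups on the shared core. In a functional assay on OVCAR-3 cells (Homo sapiens) for inhibition, read by sulforhodamine B assay, with a stated time of 48 h (on this read-out lower numbers stand for stronger inhibition and higher numbers for weaker inhibition), compound 2 gives 65200 nM, the lowest of the two numbers recorded so far; the nearest is compound 1 `O=c1c(C2N=C(c3ccccc3)SS2)coc2ccc(Cl)cc12`, which in this assay gives 66500 nM. Within the data shown here, the one step within the pair, a 1.0-fold lower number from compound 1 to compound 2 (0.01 log units; within the scatter), shows that adding a chloro to the shared core of compound 1 left the number unchanged.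

Compound 3 `O=c1c(C2N=C(c3ccccc3)SS2)coc2cc(Cl)ccc12` is the next point: hydrogen in place of chloro on an aromatic carbon. Among the measured compounds shown here, this removal of a chloro is the reverse kind of change to the only measured step, which was flat, so no step beyond the scatter is expected in this assay. The expected step is therefore a 1.0-fold higher number from compound 2 to compound 3 (0.01 log units; within the scatter). On that basis compound 3 is estimated at 66000 nM, with a range from 30000 nM to 150000 nM.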

Compound 3, half-maximal inhibitory concentration: 10500 nM
Compound 3: the middle estimate sits 6.3-fold (0.80 log units) above what was measured, and the stated range ends above it.
By their numbers in this assay, from the lowest: compound 3; then compounds 2 and 1 (each within the scatter of the next).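

Replacing the chloro on this carbon, which is ortho to a chloro group and para to a fused ring, with hydrogen gives a 6.2-fold lower number from compound 2 to compound 3 (0.79 log units; beyond the scatter) in this assay. The flat step a 1.0-fold lower number from compound 1 to compound 2 (0.01 log units; within the scatter) therefore does not carry over to this carbon: the two chloro groups of compound 2 do not count alike, and here the form with hydrogen gives the lower number. Nothing at hand bears on the origin of this difference.

The compounds shown place only hydrogen or chloro on this carbon, so it remains open how a fluoro, a methoxy or an amine there would read in this assay. Also open, going by these compounds, is whether the same change would give a step of similar size with the phenyl group of the shared core replaced by another group.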